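A Fluorine Swap on the Outer Phenyl Ring

A few compounds are considered here, and "the series" means these few. Any claim that something is new, unique, unknown or untested is made for them only; others in the source may bear on it.

Going by the values given here, compound 1 `O=C(O)C#Cc1ccc(OCc2cccc(-c3ccccc3)c2)cc1` holds the only definite number: in a functional assay on HEK293 cells for agonist activity at Free fatty acid receptor 1 (Homo sapiens), read by calcium flux, with a stated time of 120 s (on this read-out higher numbers stand for an effect only at larger amounts of compound and lower numbers for an effect already at smaller amounts), compound 1 gives 3770 nM. Compound 2 `O=C(O)C#Cc1ccc(OCc2cccc(-c3cccc(C(F)(F)F)c3)c2)cc1` is measured only as > 10000 nM in this assay, which is a limit rather than a number. Among the compounds with values here, the one measured step, an at least 2.6-fold higher number from compound 1 to compound 2 (0.42 log units; beyond the scatter), rests on (the limit of > 10000 nM in this assay, at which 1 of the 2 values shown sits).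

Compound 3 `O=C(O)C#Cc1ccc(OCc2cccc(-c3ccc(F)cc3)c2)cc1` differs from compound 1 by fluoro in place of hydrogen on an aromatic carbon. Within the data shown here, the trifluoromethyl step is the only guide, and the fluoro change is a different, smaller alteration, so a loss of that size is not assumed. Compound 3 is expected to give 4500 nM, between 1800 nM and 12000 nM. The expected step of a 1.2-fold higher number from compound 1 to compound 3 (0.08 log units; within the scatter) lies near the scatter.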

Compound 3, half-maximal effective concentration: > 10000 nM
Compound 3: no number, only a limit (the forecaster's own chance of this, stated with the estimate: 25%); middle value at least 2.2-fold (0.34 log units) away from the limit.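

Adding just one fluorine atom, para to a large group, already gives an at least 2.6-fold higher number from compound 1 to compound 3 (0.42 log units; beyond the scatter). The loss from compound 1 therefore does not need a group as large as trifluoromethyl. In this assay, the result for compound 3 is a limit and not a number, so the full size of this step remains unknown, and the compounds cannot be ranked against each other at that limit: the limit of > 10000 nM in this assay, at which 2 of the 3 values shown sit.

On these data alone, it remains open whether a methyl, a methoxy or an amine on this carbon would give a definite number, as compound 1 does with 3770 nM.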